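Compound 3 to compound 4: a new group on the urea

A few compounds are considered here, and "the series" means these few. Any claim that something is new, unique, unknown or untested is made for them only; others in the source may bear on it.

Values in a functional assay on MCF7 cells (Homo sapiens) for antiproliferative activity, read by MTT assay; a lower number here means a stronger inhibitor, a higher number a weaker inhibitor:
- compound 1 `COc1cc2c(Oc3ccc(NC(=O)Nc4cccc(C)c4)cc3)ccnc2cc1OCCCCCCC(=O)NO`: 1240 nM
- compound 2 `COc1cc2c(Oc3ccc(NC(=O)Nc4ccccc4C(F)(F)F)cc3)ccnc2cc1OCCCCCCC(=O)NO`: 1080 nM
- compound 3 `COc1cc2c(Oc3ccc(NC(=O)Nc4ccc(Cl)c(C(F)(F)F)c4)cc3)ccnc2cc1OCCCCCCC(=O)NO`: 5150 nM

Compound 3 has the highest number of the three. Its two neighbours do not separate from each other, with a 1.1-fold lower number from compound 1 to compound 2 (0.06 log units; within the scatter). The steps up to compound 3 are a 4.2-fold higher number from compound 1 to compound 3 (0.62 log units; beyond the scatter) and a 4.8-fold higher number from compound 2 to compound 3 (0.68 log units; beyond the scatter).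

Compound 4 `COc1cc2c(Oc3ccc(NC(=O)N/N=C/c4ccccc4)cc3)ccnc2cc1OCCCCCCC(=O)NO` keeps the shared core and the hydroxamic acid chain of compound 3 and changes only the group on the amide-type nitrogen: a group of 8 heavy atoms (7 carbon, 1 nitrogen; one six-membered aromatic ring of carbon only) in place of a group of 11 heavy atoms (7 carbon, 3 fluorine, 1 chlorine; one six-membered aromatic ring of carbon only), on an amide-type nitrogen. The 4-chloro-3-(trifluoromethyl)phenyl group leaves, and the entering group has no common name. Among the compounds with values here, it brings a double bond outside aromatic rings, and no measured compound carries anything like it, so the data give no direct step for this change.

The nearest evidence is the pair of steps already given, a 4.2-fold higher number from compound 1 to compound 3 (0.62 log units; beyond the scatter) and a 4.8-fold higher number from compound 2 to compound 3 (0.68 log units; beyond the scatter). Read backwards, they show that both other groups tested at this place sit lower than compound 3. Within the data shown here, with only those two comparisons, a modest move to a lower number is expected in this assay, no larger than those steps, and the expected step is a 2.3-fold lower number from compound 3 to compound 4 (0.37 log units; beyond the scatter). Compound 4 is estimated at 2200 nM, with an expected range of 800 nM to 6000 nM.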

Compound 4, half-maximal inhibitory concentration: 610 nM
Compound 4: middle estimate off by 3.6-fold (0.56 log units), on the high side, outside the stated range (below it).
By their numbers in this assay, from the lowest: compounds 4, 2 and 1 (each within the scatter of the next, the first and the last beyond it); then compound 3.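

In this assay the amide-type nitrogen whose other neighbour is the carbonyl carbon is shown to accept more than a directly attached substituted phenyl: the entering group, with its double bond outside aromatic rings and its hydrogen-bond acceptor, gives an 8.4-fold lower number from compound 3 to compound 4 (0.93 log units; beyond the scatter) and so removes the high number seen with the 4-chloro-3-(trifluoromethyl)phenyl group. Against the other two groups the change is much smaller: a 1.8-fold lower number from compound 2 to compound 4 (0.25 log units; within the scatter) does not separate the two compounds, while a 2.0-fold lower number from compound 1 to compound 4 (0.31 log units; beyond the scatter) only just clears the scatter, so compound 3 remains the only clear outlier among the four compounds. Nothing at hand explains the size of these steps or accounts for the separation of compound 3 from the rest.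

The series leaves open whether the step from compound 3 to compound 4 survives when the ring of the entering group carries a chlorine or a trifluoromethyl, a comparison that would separate the ring substituents from the atoms linking that ring to the urea. It also leaves open how a pyridine ring in place of that carbon-only ring, or a methyl group on the carbon of the double bond, would read in this assay.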